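The compounds below may be only part of what the source reports. "The series", "measured", "known", "first", "only" and "open" are said of these compounds alone.

Compound 2 `Cc1cc(C(=O)Nc2cccc(-c3oc4cc(-c5ccc(F)cc5)ccc4c(=O)c3O)c2)ccc1F` is one of two compounds measured in a functional assay on HCC1937 cells (Homo sapiens) for antiproliferative activity, read by CCK-8 assay, with a stated time of 72 h (on this read-out lower numbers stand for stronger inhibition and higher numbers for weaker inhibition), where compound 2 gives 5420 nM, the lowest of the two numbers shown. Compound 1 `COc1ccccc1C(=O)Nc1cccc(-c2oc3cc(-c4ccc(F)cc4)ccc3c(=O)c2O)c1` gives 9050 nM in this assay, and the step of a 1.7-fold lower number from compound 1 to compound 2 (0.22 log units; within the scatter) stays within the scatter, so the two compounds cannot be told apart on these numbers. Compound 3 `Cc1cc(C)cc(C(=O)Nc2cccc(-c3oc4cc(-c5ccc(F)cc5)ccc4c(=O)c3O)c2)c1` differs from compound 2 in one place: 3,5-dimethylphenyl in place of 4-fluoro-3-methylphenyl on a carbonyl carbon. For the measured compounds named here, the only measured step that bears on this change is a 1.7-fold lower number from compound 1 to compound 2 (0.22 log units; within the scatter), which also exchanged one phenyl-type group on that carbonyl carbon for another and produced no movement beyond the scatter. On that basis the step is expected to be a 1.0-fold higher number from compound 2 to compound 3 (0.01 log units; within the scatter), with no direction beyond the scatter. Compound 3 is therefore estimated at 5500 nM in this assay, with a range from 2500 nM to 12000 nM.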

Compound 3, half-maximal inhibitory concentration: 4860 nM
Compound 3: the middle estimate sits 1.1-fold (0.05 log units) above what was measured; the range from low to high includes it.
By their numbers in this assay, from the lowest: compounds 3, 2 and 1 (each within the scatter of the next).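

Placing 3,5-dimethylphenyl on the carbonyl carbon in place of 4-fluoro-3-methylphenyl gives a 1.1-fold lower number from compound 2 to compound 3 (0.05 log units; within the scatter) in this assay and so adds a third phenyl-type group, this one of carbon only, that cannot be told apart from the others. Even the step between the two groups not yet compared directly, a 1.9-fold lower number from compound 1 to compound 3 (0.27 log units; within the scatter) and still within the scatter, shows no exchange among these three groups that moves the number beyond it. Nothing measured here explains this lack of separation.

From the compounds shown here alone, all three compounds keep a six-membered aromatic carbon ring on that carbonyl carbon, so it remains open whether a saturated cyclohexyl group, or a phenyl ring carrying an amine or a carboxylic acid, would shift the number beyond the scatter. Going by these compounds, the shared core is also the same throughout, so the effect of changes there remains open as well.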